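Swapping an iodine for a basic amine arm on a phenol

A few compounds are considered here, and "the series" means these few. Any claim that something is new, unique, unknown or untested is made for them only; others in the source may bear on it.

Of the compounds shown here, three sharing one phenol core have been measured in a physicochemical assay for lipophilicity; on this read-out higher numbers stand for higher lipophilicity and lower numbers for lower lipophilicity. Compound 1, `CC(C)c1cc(I)cc(C(C)C)c1O`, gives 5.75. Compound 2, `CC(C)c1cc([N+](=O)[O-])cc(C(C)C)c1O`, gives 4.71. Compound 3, `CC(C)c1cc(C(=O)c2ccccc2)cc(C(C)C)c1O`, gives 5.91. Compound 1 therefore sits among the higher numbers of the three: its value and that of compound 3 cannot be told apart within the scatter, while compound 2 lies well beneath it, with a number 1.04 log units lower from compound 1 to compound 2 (beyond the scatter).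

Compound 4, `CC(C)c1cc(CN(C)C)cc(C(C)C)c1O`, has not yet been measured in this assay. It differs from compound 1 in one place: (dimethylamino)methyl in place of iodo on an aromatic carbon. Within the data shown here, the only measured step that speaks to this change is the one from compound 1 to compound 2, where the iodo group also left and a small polar group took its place, and the number fell by a large amount, beyond the scatter. The (dimethylamino)methyl group brings a hydrogen-bond acceptor, as the nitro group did, so a drop of similar character is expected here. The step from compound 1 to compound 4 is estimated as a number 1.25 log units lower from compound 1 to compound 4 (beyond the scatter). Compound 4 is thus expected to give about 4.5, within a range from 3.9 to 5.1.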

Compound 4, partition coefficient: 2.5
Beside the measured number, compound 4's estimate is 2.00 log units above it; measured number below the stated range.
By their numbers in this assay, from the lowest: compound 4; then compound 2; then compounds 1 and 3 (each within the scatter of the next).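

In this assay, among these compounds, the carbon para to a hydroxy group and meta to two isopropyl groups proves able to carry a far wider spread of numbers than the earlier compounds showed: (dimethylamino)methyl in place of iodo gives a number 3.25 log units lower from compound 1 to compound 4 (beyond the scatter). The new compound also falls well past the nitro compound, with a number 2.21 log units lower from compound 2 to compound 4 (beyond the scatter), so leaving iodo behind does not set the size of the drop at this position, and the group that enters makes a large difference. Among the compounds shown here, nothing available here accounts for why this change moves the number so far.

The compounds shown do not separate the contribution of the nitrogen from that of the rest of the arm, and an isobutyl group, which has carbon where (dimethylamino)methyl has its nitrogen, would be the direct comparison. Also open, as far as these compounds go, is how the number responds to other arms at this same carbon, such as a plain aminomethyl group, a longer chain between the ring and the dimethylamino group, or a carboxylic acid.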